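The compounds below may be only part of what the source reports. "The series", "measured", "known", "first", "only" and "open" are said of these compounds alone.

In an ADME assay on MT4 cells (Homo sapiens) for activation, read by MTT assay (a higher number here means that more compound is tolerated, a lower number that less compound is tolerated), compound 1 `CCCSc1nc(Cc2c(F)cccc2Cl)cc(=O)[nH]1` gives > 80000 nM, which is a limit of the assay and not a number. Compound 2 `CCCSc1nc(Cc2c(F)cccc2Cl)c(C)c(=O)[nH]1` gives > 76000 nM, again only a limit, so its standing cannot be put as a number. Among the compounds with values here, the sole measured step, a step that the two limits leave unreadable from compound 1 to compound 2, places methyl in place of hydrogen on an aromatic carbon and offers no size to carry forward. Compound 3 `Cc1c(Cc2c(F)cccc2Cl)nc(SC2CCCC2)[nH]c1=O` changes another part of compound 2: cyclopentyl in place of propyl on a sulfur. Within the data shown here, no measured step touches this group. The reasoning therefore rests on compound 2 with its limit of > 76000 nM, and no change beyond the scatter is expected in this assay. The expected size is an at least 1.0-fold lower number from compound 2 to compound 3 (0.03 log units; that floor lies within the scatter). Compound 3 is estimated at 70000 nM, within an expected range of 25000 nM to 160000 nM.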

Compound 3, half-maximal cytotoxic concentration: > 71000 nM
Compound 3: only a limit was reported (the forecaster's own chance of this, stated with the estimate: 60%); at least 1.0-fold (0.00 log units) between middle value and limit.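

In this assay compound 3 gives > 71000 nM, which is a limit and not a number. Within the data shown here, compound 2 also stands only as a limit, so no step from it to compound 3 can be read. The compounds shown leave open whether cyclopentyl in place of propyl on a sulfur changes the half-maximal cytotoxic concentration at all.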